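The source may report more compounds than this note shows. Statements on the series, on what has been measured and on what is new or still open speak of the compounds shown alone.

The series shares one core; compound 1 `COc1ccc(-c2cc(=O)c3c(OC)cc(OC)cc3n2S(=O)(=O)c2ccc(C=O)cc2)cc1`, compound 2 `COc1ccc(-c2cc(=O)c3c(OC)cc(OC)cc3n2S(=O)(=O)c2ccc(C)c([N+](=O)[O-])c2)cc1` and compound 3 `COc1ccc(-c2cc(=O)c3c(OC)cc(OC)cc3n2S(=O)(=O)c2c(F)c(F)c(F)c(F)c2F)cc1` differ only in the aryl group on the sulfonyl sulfur. In a functional assay on HepG2 cells (Homo sapiens) for antiproliferative activity, with a stated time of 72 h (a higher number here means that more compound is needed for the effect, a lower number that less compound is needed), compound 1 gives > 34400 nM, which is a limit of the assay and not a number. Compound 2 gives > 51700 nM, again a limit. Compound 3 gives > 34400 nM, also a limit. Compound 3 thus stands only at a limit, as do the two other values shown, and the steps a step that the two limits leave unreadable from compound 1 to compound 2, a step that the two limits leave unreadable from compound 1 to compound 3 and a step that the two limits leave unreadable from compound 2 to compound 3 cannot be read. The two limits in play are the limit of > 34400 nM in this assay, at which 2 of the 3 values shown sit, and (the limit of > 51700 nM in this assay, at which 1 of the 3 values shown sits). Compound 4 `COc1ccc(-c2cc(=O)c3c(OC)cc(OC)cc3n2S(=O)(=O)c2cc(Cl)cc(Cl)c2O)cc1` is not yet measured; it differs from compound 3 by 3,5-dichloro-2-hydroxyphenyl in place of 2,3,4,5,6-pentafluorophenyl on a sulfonyl sulfur. Among the compounds with values here, no measured step bears on this change; the three measured values are all limits and none shows a gain beyond the scatter. Compound 4 is therefore expected to sit near the limit as well, at an estimated 40000 nM with a range from 10000 nM to 120000 nM. The step thus expected, a step that the limit leaves unreadable from compound 3 to compound 4, would stay within the scatter.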

Compound 4, half-maximal effective concentration: > 37900 nM
Compound 4 gave a limit, no number (the forecaster's own chance of this, stated with the estimate: 80%); the middle value does not contradict the limit.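

Compound 4 gives a limit and not a number in this assay, as do compound 1, compound 2 and compound 3, so none of the steps to compound 4 can be read. The compounds shown leave open whether any aryl group on the sulfonyl sulfur gives a measurable antiproliferative value, and how these groups rank.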